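From Acetamidophenyl to Trifluorophenyl on the Ether Oxygen

The source may hold more compounds than are shown below. What is called first, only, known or untested is meant among the compounds shown, and "the series" means these compounds.

Of the compounds shown here, three built on a shared core have been tested in a functional assay on Jurkat cells (Homo sapiens); on this read-out lower numbers stand for stronger inhibition and higher numbers for weaker inhibition. Compound 1 `CC(C)[C@H](NC(=O)COc1cccc2ccccc12)C(=O)N[C@@H](CC(=O)O)C(=O)COc1cc(C(F)(F)F)cc(C(F)(F)F)c1` returns only a limit in this assay, > 100000 nM. Compound 2 `CC(C)[C@H](NC(=O)COc1cccc2ccccc12)C(=O)N[C@@H](CC(=O)O)C(=O)COc1ccc(Oc2ccc(C(F)(F)F)cc2)cc1` gives 9300 nM in this assay. Compound 3 `CC(=O)Nc1cccc(OCC(=O)[C@H](CC(=O)O)NC(=O)[C@@H](NC(=O)COc2cccc3ccccc23)C(C)C)c1` likewise returns only a limit, > 100000 nM. Compound 3 therefore stands at the limit of > 100000 nM in this assay, at which 2 of the 3 values shown sit, and of the three values shown only compound 2 provides an actual number. Going by the values given here, no two of these measured compounds differ in a single place, so no measured step is available to lean on.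

Compound 4 `CC(C)[C@H](NC(=O)COc1cccc2ccccc12)C(=O)N[C@@H](CC(=O)O)C(=O)COc1cc(F)cc(F)c1F` has not yet been measured in this assay. Its difference from compound 3 is counted as follows: 2,3,5-trifluorophenyl in place of 3-acetamidophenyl on an oxygen on a saturated carbon. The exchange sits on an oxygen on a saturated carbon whose other neighbour is a saturated chain carbon, and the 3-acetamidophenoxy of compound 3 becomes the 2,3,5-trifluorophenoxy of compound 4.

Among the compounds with values here, since compound 3 rests at a limit, no step can be computed for it. Among the compounds shown, only compound 2 carries a fluorine-bearing aryl group and also yields a measurable value. The expected step is an at least 50-fold lower number from compound 3 to compound 4 (1.69 log units; beyond the scatter), towards stronger inhibition and beyond the usual scatter. Compound 4 is estimated at 2000 nM, with a range from 200 nM to 30000 nM.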

Compound 4, half-maximal inhibitory concentration: 30000 nM
Estimate against measurement, compound 4: 15-fold (1.18 log units) below; measured number inside the range.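

The exchange on an oxygen on a saturated carbon gives, in this assay, an at least 3.3-fold lower number from compound 3 to compound 4 (0.52 log units; beyond the scatter), so this position can bring a compound off the limit with an aryl group that carries 0 hydrogen-bond donors and 0 hydrogen-bond acceptors, and the 3-acetamidophenyl with its donor and acceptor is not required for a measurable value. The size of this change is known only as a floor, since compound 3 holds a limit rather than a number: the limit of > 100000 nM in this assay, at which 2 of the 4 values shown sit.

Fluorine on the aryl group does not by itself secure a measurable value, and compound 1 goes against any such pattern with > 100000 nM, which is a limit and not a number.

The compounds shown leave open whether the gain comes from the entering fluorines or simply from the departure of the acetamido group, and an unsubstituted phenyl or a 3-aminophenyl on the same oxygen would separate the two. They also leave open how the number of fluorines on the ring counts, which a monofluorophenyl or a pentafluorophenyl in this place would address.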